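A few compounds are considered here, and "the series" means these few. Any claim that something is new, unique, unknown or untested is made for them only; others in the source may bear on it.

Three compounds have been measured so far:

Compound 1 `O=C(O)/C=C/c1ccc(NCc2cccc(Oc3ccccc3)c2)cc1` gives 76% in a functional assay on CHO cells for agonist activity at Free fatty acid receptor 1 (Homo sapiens), read by a luciferase reporter; on this read-out lower numbers stand for smaller maximal responses and higher numbers for larger maximal responses.
Compound 2 `Cc1nc(-c2ccc(C(F)(F)F)cc2)sc1CNc1ccc(/C=C/C(=O)O)cc1` gives 95% in this assay.
Compound 3 `O=C(O)COc1ccc(NCc2cccc(Oc3ccccc3)c2)cc1` gives 84% in this assay.

Compound 1 and compound 3 share a core and differ at one point only: carboxymethoxy in place of 2-carboxyethenyl on an aromatic carbon. This change gave a number 8 percentage points higher from compound 1 to compound 3 (within the scatter). Compound 2 carries a different core, and how its core differs from that of compound 1 is not broken down here. In this assay compound 2 stands highest of the three, beyond the scatter from both others.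

Compound 4 `Cc1nc(-c2ccc(C(F)(F)F)cc2)sc1CNc1ccc(OCC(=O)O)cc1` has not yet been measured. It differs from compound 2 by carboxymethoxy in place of 2-carboxyethenyl on an aromatic carbon, the same change as between compound 1 and compound 3, at a place described in the same words. Because a number 8 percentage points higher from compound 1 to compound 3 (within the scatter), a step of about a number 4 percentage points higher from compound 2 to compound 4 (within the scatter) is expected. Compound 4 is therefore expected to give 99%, likely between 86% and 112%.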

Compound 4, largest response reached (reported as percent of maximum), in percent of the reference or control that the assay uses: 100%
Estimate against measurement, compound 4: 1 percentage points below; the measured number falls inside the stated range.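

Replacing 2-carboxyethenyl with carboxymethoxy gave a number 5 percentage points higher from compound 2 to compound 4 (within the scatter) in this assay. Set beside the earlier step, the change looks alike on the two cores: the same change on two cores in this assay, a number 8 percentage points higher (within the scatter) from compound 1 to compound 3 and a number 5 percentage points higher (within the scatter) from compound 2 to compound 4, 3 percentage points apart, within the scatter of two such steps

So on these two cores, the swap carries over with no shift beyond the usual scatter, but two pairs cannot show that it would behave the same way on any other core, and neither step shows that one of the two groups gives a larger response than the other.

The compounds shown leave open whether an amide or a tetrazole could stand in place of the carboxylic acid, and whether a longer chain carrying the acid would keep the response. They also leave open how much compound each needs to reach its response, since this read-out gives only the largest response.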